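The compounds below may be only part of what the source reports. "The series", "measured", "known", "first", "only" and "open" are said of these compounds alone.

Two compounds set the frame. In an assay on isolated protein for inhibition of leukotriene C4 synthase (Homo sapiens), read by LC-MS, with stated times of 45 min and 20 min (a higher number here means a weaker inhibitor, a lower number a stronger inhibitor), compound 1 `COc1cc(N(CC2CC2)c2ccccc2)cnc1C(=O)[C@H]1C[C@@H]1C(=O)O` gives 1640 nM. In this assay compound 2 `COc1cc(N(CC(C)C)c2cccc(C(F)(F)F)c2)cnc1C(=O)[C@H]1C[C@@H]1C(=O)O` gives 20.6 nM, the lower of the two numbers, and its gap to compound 1 lies beyond the scatter. Compound 3 `CCCN(c1cccc(C(F)(F)F)c1)c1cnc(C(=O)[C@H]2C[C@@H]2C(=O)O)c(OC)c1` differs from compound 2 by hydrogen in place of methyl on a saturated chain carbon bound to two saturated chain carbons. Among the compounds with values here, no measured pair shows this change, so its size is untested. In this assay the expected step is a small one of about a 1.7-fold higher number from compound 2 to compound 3 (0.23 log units; within the scatter), toward a weaker inhibitor and not clearly beyond the scatter. Compound 3 is therefore expected to give about 35 nM in this assay, plausibly between 12 nM and 100 nM.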

Compound 3, half-maximal inhibitory concentration: 58.4 nM
For compound 3 the middle estimate is 1.7-fold (0.22 log units) below the measured one, within the range that was stated.
By their numbers in this assay, from the lowest: compound 2; then compound 3; then compound 1.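

In this assay, cutting isobutyl back to propyl gives a 2.8-fold higher number from compound 2 to compound 3 (0.45 log units; beyond the scatter), so this methyl has a measurable effect on the number, though a modest one. Within the data shown here, this is the first measured size for the change, and the loss of this one carbon moves the compound toward a weaker inhibitor. Nothing available gives a reason for this step. The compounds shown leave open how a longer chain or a chain holding an ether oxygen would fare in this place. They also leave open whether this change would have the same size on a compound without the trifluoromethyl group.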